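A Nitro Replaced by Diethylamino on the Benzamide Ring

The source may hold more compounds than are shown below. What is called first, only, known or untested is meant among the compounds shown, and "the series" means these compounds.

Of the compounds shown here, three of a shared core have been measured in an assay on HEK293 cells for antagonist activity at P2X purinoceptor 7 (Homo sapiens), read by fluorescence, with a stated time of 2 h; a lower number here means a stronger inhibitor, a higher number a weaker inhibitor. Compound 1 `O=C(c1ccc(Cl)c(C(F)(F)F)c1)N1CCC(n2cncc2-c2ccc(OS(=O)(=O)c3cccc4ccccc34)cc2)CC1` gives 3520 nM. Compound 2 `COc1ccc(C(=O)N2CCC(n3cncc3-c3ccc(OS(=O)(=O)c4cccc5cnccc45)cc3)CC2)cc1` gives 77 nM, and compound 3 `O=C(c1ccc([N+](=O)[O-])cc1)N1CCC(n2cncc2-c2ccc(OS(=O)(=O)c3cccc4cnccc34)cc2)CC1` gives 1.49 nM. Compound 3 thus carries the lowest number of the three; compound 2 stands nearest to it and compound 1 furthest away.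

Among the measured compounds shown here, the one single-site step in this set is a 52-fold lower number from compound 2 to compound 3 (1.71 log units; beyond the scatter). Compound 4 `CCN(CC)c1ccc(C(=O)N2CCC(n3cncc3-c3ccc(OS(=O)(=O)c4cccc5cnccc45)cc3)CC2)cc1` is the next compound, and it differs from compound 3 by diethylamino in place of nitro on an aromatic carbon. For the measured compounds named here, the change sits at the same position as the step from compound 2 to compound 3, and it again removes the nitro group that compound 3 holds there, so that only that one step bears on it. Since the exchange of methoxy for nitro lowered the number by a large amount, an exchange of nitro for another group at that position is expected to push the number of compound 4 back up in this assay, though by how much cannot be read from a single step. Compound 4 is therefore estimated at 50 nM, within a range of 10 nM to 250 nM, which is a step of a 34-fold higher number from compound 3 to compound 4 (1.53 log units; beyond the scatter) and is expected to fall short of the value of compound 2.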

Compound 4, half-maximal inhibitory concentration: 1440 nM
Compound 4: middle estimate off by 29-fold (1.46 log units), on the low side; the measured number lies above the stated range.
By their numbers in this assay, from the lowest: compound 3; then compound 2; then compound 4; then compound 1.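

In this assay, among the compounds shown here, the carbon para to a large group on this ring now has three readings on one core, and a 970-fold higher number from compound 3 to compound 4 (2.99 log units; beyond the scatter) is much larger than the single step known before. The loss of nitro does not account for the whole spread, since a 19-fold higher number from compound 2 to compound 4 (1.27 log units; beyond the scatter) shows that the two groups other than nitro also stand apart beyond the scatter. Among these three compounds the numbers rise from nitro through methoxy to diethylamino, so the choice of group at this position can move the number very far in either direction, but no measurement shown explains this order.

The compounds shown leave open where a smaller amine such as dimethylamino or an unsubstituted amino group would fall at this carbon, and whether a nitrile or a carboxylic acid there would come close to the low number of nitro. They also leave open whether the same order would hold if another part of the shared core were changed, as compound 1 differs from these three in more than one place.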